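FXR agonist notes: aminopyridine-linked isoxazoles, step to compound 3

The source may report more compounds than this note shows. Statements on the series, on what has been measured and on what is new or still open speak of the compounds shown alone.

Measured so far:
compound 1 `Cc1nc(OCc2c(-c3c(Cl)cccc3Cl)noc2C(C)C)ccc1N(C)C(=O)c1ccc(C(=O)O)cc1`: 2030 nM
compound 2 `CC(C)c1onc(-c2c(Cl)cccc2Cl)c1COc1ccc(N(C)C(=O)c2cccc(C(=O)O)c2)c(C(F)(F)F)n1`: 571 nM

Both compounds were tested in a functional assay on HEK293 cells for agonist activity at Bile acid receptor (Homo sapiens); on this read-out higher numbers stand for an effect only at larger amounts of compound and lower numbers for an effect already at smaller amounts. Compound 1 `Cc1nc(OCc2c(-c3c(Cl)cccc3Cl)noc2C(C)C)ccc1N(C)C(=O)c1ccc(C(=O)O)cc1` gives 2030 nM. Compound 2 `CC(C)c1onc(-c2c(Cl)cccc2Cl)c1COc1ccc(N(C)C(=O)c2cccc(C(=O)O)c2)c(C(F)(F)F)n1` gives 571 nM, the lower of the two numbers; the gap between compound 1 and compound 2 is beyond the usual scatter, so compound 2 stands as the more potent of the pair on this read-out. Among the compounds with values here, the two compounds differ in more than one place, so no single step can be assigned to this gap.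

The next compound, compound 3 `CC(C)c1onc(-c2c(Cl)cccc2Cl)c1COc1ccc(N(C)Cc2ccc(OCCO)cc2)c(C(F)(F)F)n1`, keeps the core of compound 2 and changes only the group on the ring nitrogen: 4-(2-hydroxyethoxy)benzyl in place of (3-carboxyphenyl)carbonyl on a nitrogen on an aromatic ring

Within the data shown here, no measured step of this kind is available, so the expectation rests on compound 2 alone. The exchange removes the carbonyl and the carboxylic acid that both measured compounds carry, and this is expected to give a step toward weaker agonism, beyond the scatter, of about a 3.5-fold higher number from compound 2 to compound 3 (0.54 log units; beyond the scatter) in this assay. Compound 3 is therefore estimated at 2000 nM in this assay, with a range from 500 nM to 8000 nM.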

Compound 3, half-maximal effective concentration: 1150 nM
Estimate against measurement, compound 3: 1.7-fold (0.24 log units) above; measured number inside the range.
By their numbers in this assay, from the lowest: compounds 2, 3 and 1 (each within the scatter of the next, the first and the last beyond it).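

In this assay, within the data shown here, replacing (3-carboxyphenyl)carbonyl with 4-(2-hydroxyethoxy)benzyl on the nitrogen gives a 2.0-fold higher number from compound 2 to compound 3 (0.30 log units; within the scatter), the first single-place step at this position, so for this pair, a number within the scatter of compound 2 does not depend on the carbonyl or the carboxylic acid. The two groups match in heavy atoms, in six-membered aromatic rings of carbon only, and in hydrogen-bond donors and acceptors, but they differ in composition and in the double bonds outside aromatic rings, so this position accepts at least two differently built substituents of the same size on this read-out. Nothing available bears on why the two groups give numbers within the scatter of each other.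

This single step changes the carbonyl, the acid and the hydroxyethoxy chain together, so the contribution of each cannot be separated. Still open, going by these compounds, is how a plain benzyl, a benzyl carrying a carboxylic acid, or a longer chain ending in an amine would read at this nitrogen in this assay.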